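A Ring Swap Beneath a Clearance Limit

This account rests on a few compounds, and the source may have more. Where it says the series, first, only, none or still open, it means among the compounds named here.

In an in vitro ADME assay on microsomes from Gut (Homo sapiens) for metabolic stability, using NADPH (a higher number here means faster removal of the compound, a lower number slower removal), compound 2 `COc1ccc(C)cc1Cn1c(C(=O)NCC(C)(C)CO)cc2cc(C#N)ccc21` gives < 6 mL.min-1.g-1, which is a limit and not a number. Compound 1 `COc1ccc(Cl)cc1Cn1c(C(=O)NCC(C)(C)CO)cc2cc(C#N)ccc21` gives < 6 mL.min-1.g-1, also a limit. Among the compounds with values here, the evidence is therefore (the limit of < 6 mL.min-1.g-1 in this assay, at which 2 of the 2 values shown sit), and the one measured step, a step that the two limits leave unreadable from compound 1 to compound 2, has no readable size. Compound 3 `Cc1ccc(Cl)cc1Cn1c(C(=O)NCC(C)(C)CO)cc2cc(C#N)ccc21` brings (5-chloro-2-methylphenyl in place of 2-methoxy-5-methylphenyl on a saturated chain carbon bound to an aromatic nitrogen), with 5-chloro-2-methylphenyl in place of 2-methoxy-5-methylphenyl. With no measured size to scale from, no step beyond the scatter is expected in this assay. The expected change is a step that the limit leaves unreadable from compound 2 to compound 3. Compound 3 is estimated at 5 mL.min-1.g-1, within an expected range of 2.5 mL.min-1.g-1 to 10 mL.min-1.g-1.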

Compound 3, intrinsic clearance in microsomes: < 6 mL.min-1.g-1
Compound 3 gave a limit, no number; the forecaster's own chance of this, stated with the estimate: 70%; the middle value is on the limit's open side.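

Within the data shown here, compound 1, compound 2 and compound 3 each give a limit and not a number, so no step between them can be read. Going by these compounds, whether these three compounds truly differ in this assay stays open.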